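The source may report more compounds than this note shows. Statements on the series, on what has been measured and on what is new or still open speak of the compounds shown alone.

Compound 3, `N#C/C(=C\c1c(-c2ccccc2)[nH]c2ccccc12)S(=O)(=O)c1ccccc1`, is the reference point for the step that follows. Going by the values given here, in a functional assay on NCI-H460 cells (Homo sapiens) for inhibition, read by sulforhodamine B assay, with a stated time of 48 h (a lower number here means a stronger inhibitor of growth, a higher number a weaker inhibitor of growth), compound 3 gives 2700 nM, which places it second highest among the three numbers measured so far. Its nearest neighbour is compound 2, `COc1ccc2[nH]c(-c3ccccc3)c(/C=C(\C#N)S(=O)(=O)c3ccccc3)c2c1`, which in this assay gives 4600 nM; the gap between compound 2 and compound 3, a 1.7-fold lower number from compound 2 to compound 3 (0.23 log units; within the scatter), lies within the scatter. Its furthest neighbour is compound 1, `COc1ccc(-c2[nH]c3ccccc3c2/C=C(\C#N)S(=O)(=O)c2ccccc2)cc1`, which in this assay gives 404 nM; the step of a 6.7-fold higher number from compound 1 to compound 3 (0.82 log units; beyond the scatter) is beyond the scatter. Both of these measured steps concern the same kind of change, hydrogen in place of methoxy on an aromatic carbon, and say nothing about the part of the molecule that is altered next.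

Compound 4, `N#C/C(=C\c1c(-c2ccccc2)[nH]c2ccccc12)C(=O)c1ccccc1`, differs from compound 3 in one place: benzoyl in place of phenylsulfonyl on a double-bonded chain carbon bound to a double-bonded chain carbon and a triple-bonded carbon. Among the compounds with values here, none of the measured steps bears on this exchange, so the direction of the step in this assay cannot be read from the compounds in hand. With no basis for expecting a shift, the number for compound 4 is estimated near that of compound 3, with a wide range to reflect this, as a step of no change at the digits printed from compound 3 to compound 4 (within the scatter). Compound 4 is therefore expected at about 2700 nM, between 700 nM and 10000 nM.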

Compound 4, concentration for 50% growth inhibition: 4500 nM
Compound 4: middle estimate off by 1.7-fold (0.22 log units), on the low side; the range from low to high includes it.
By their numbers in this assay, from the lowest: compound 1; then compounds 3, 4 and 2 (each within the scatter of the next).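

In this assay, going by these compounds alone, the exchange gives a 1.7-fold higher number from compound 3 to compound 4 (0.22 log units; within the scatter), the first measured step at this carbon, as the earlier steps concerned only hydrogen in place of methoxy on an aromatic carbon. It shows that phenylsulfonyl, with 2 double bonds outside aromatic rings and 2 hydrogen-bond acceptors, can give way to benzoyl, with 1 of each, with no difference beyond the scatter, so the sulfonyl group is not needed to hold growth inhibition at the level of compound 3. Nothing measured here accounts for this result.

The compounds shown leave open whether the same exchange would also stay within the scatter on the methoxy-bearing compound 1, whose number is the lowest of the series, or on compound 2. They also leave open what a group with no phenyl ring, such as acetyl or a methyl ester, or a basic one such as a dimethylamino-bearing amide, would do on a double-bonded chain carbon bound to a double-bonded chain carbon and a triple-bonded carbon.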